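A few compounds are considered here, and "the series" means these few. Any claim that something is new, unique, unknown or untested is made for them only; others in the source may bear on it.

Measured in a functional assay on MOLT-4 cells (Homo sapiens) for inhibition, read by MTT assay, with a stated time of 4 days; a higher number here means a weaker inhibitor, a lower number a stronger inhibitor:
- compound 1 `COc1cc(NC(C)CCCNC(=O)NN)c2ncccc2c1`: >= 250000 nM
- compound 2 `O=C1NCCN1C(c1ccccc1)(c1ccccc1)c1ccccc1`: 21000 nM

In this assay, compound 1 stands at >= 250000 nM, which is a limit of the assay and not a number. Compound 3 `COc1cc(NC(C)CCCNC(=O)Nc2ccc(Cl)c(C(F)(F)F)c2)c2ncccc2c1` keeps the core of compound 1 and has 4-chloro-3-(trifluoromethyl)phenyl in place of amino on an amide-type nitrogen. Going by the values given here, no measured step bears on this change. The expected at least 20-fold lower number from compound 1 to compound 3 (1.31 log units; beyond the scatter) runs toward stronger inhibition, and its size is an estimate only. For compound 3 the estimated value is 12000 nM, with an expected range from 3500 nM to 45000 nM.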

Compound 3, half-maximal inhibitory concentration: 3400 nM
Beside the measured number, compound 3's estimate is 3.5-fold (0.55 log units) above it; the measured number lies below the stated range.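

In this assay, 4-chloro-3-(trifluoromethyl)phenyl in place of amino on an amide-type nitrogen gives an at least 73-fold lower number from compound 1 to compound 3 (1.86 log units; beyond the scatter). The group on this nitrogen therefore matters for the read-out on the shared core, which compound 1 alone could not show. The size of the step is a floor and not an exact figure: the limit of >= 250000 nM in this assay, at which 1 of the 3 values shown sits.

From the compounds shown here alone, whether the change rests on the aromatic ring itself or on its chlorine and trifluoromethyl groups stays open. An unsubstituted phenyl, a cyclohexyl or a methyl on the same nitrogen would separate these.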